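The source may hold more compounds than are shown below. What is called first, only, known or untested is meant among the compounds shown, and "the series" means these compounds.

Three compounds built on one shared core differ only in the aryl group attached to a double-bonded chain carbon bound to an aromatic carbon. Compound 3 `C=CCn1c(=O)/c(=C\c2ccccc2C(F)(F)F)[nH]c(=O)/c1=C\c1ccccc1OC` carries a 2-(trifluoromethyl)phenyl there, and in a functional assay on K562 cells (Homo sapiens) for cytotoxicity, read by CCK-8 assay, with a stated time of 72 h (on this read-out lower numbers stand for stronger inhibition and higher numbers for weaker inhibition), compound 3 gives 2700 nM, the lowest of the three numbers, though neither gap to the others reaches beyond the scatter. Compound 1 `C=CCn1c(=O)/c(=C\c2cccc(F)c2)[nH]c(=O)/c1=C\c1ccccc1OC` with a 3-fluorophenyl gives 4100 nM in this assay, and compound 2 `C=CCn1c(=O)/c(=C\c2cc(Br)ccc2F)[nH]c(=O)/c1=C\c1ccccc1OC` with a 5-bromo-2-fluorophenyl gives 5100 nM. The steps among them are small: a 1.5-fold lower number from compound 1 to compound 3 (0.18 log units; within the scatter), a 1.9-fold lower number from compound 2 to compound 3 (0.28 log units; within the scatter), and a 1.2-fold higher number from compound 1 to compound 2 (0.09 log units; within the scatter).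

Compound 4 `C=CCn1c(=O)/c(=C\c2ccc(C)cc2)[nH]c(=O)/c1=C\c1ccccc1OC` changes the same position again: 4-methylphenyl in place of 2-(trifluoromethyl)phenyl on a double-bonded chain carbon bound to an aromatic carbon. All three measured steps bear on this change, since each swaps one aryl group for another at the very same place, and none moved the number beyond the scatter. The expectation for compound 4 is therefore no step beyond the scatter, a 1.3-fold higher number from compound 3 to compound 4 (0.11 log units; within the scatter), in this assay. Compound 4 is estimated at 3500 nM in this assay, with a plausible range from 1500 nM to 8500 nM.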

Compound 4, half-maximal inhibitory concentration: "not active" (no number reported)
Nothing numeric was reported for compound 4, so the estimate cannot be set against anything.
By their numbers in this assay, from the lowest: compounds 3, 1 and 2 (each within the scatter of the next).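

In this assay, going by these compounds alone, compound 4 is recorded only as "not active", without a number, so no step from compound 3 to compound 4 can be read. No measurement shown accounts for this result. The compounds shown leave open how far compound 4, with its 4-methylphenyl, actually lies from compound 3 with its 2-(trifluoromethyl)phenyl.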